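The compounds below may be only part of what the source reports. "The series", "measured", "known", "first", "only" and "open" are said of these compounds alone.

Measured compounds:
- compound 1 `CCOc1cc(C2CCN(C)CC2)ccc1Nc1ncc2c(n1)N(Cc1ccc(Br)cc1)[C@H](CC)C(=O)N2C`: "not determined" (no result reported)
- compound 2 `CCOc1cc(C2CCN(C)CC2)ccc1Nc1ncc2c(n1)N(Cc1cccc(Cl)c1)[C@H](CC)C(=O)N2C`: 540 nM
- compound 3 `CCOc1cc(C2CCN(C)CC2)ccc1Nc1ncc2c(n1)N(Cc1cccc(OC)c1)[C@H](CC)C(=O)N2C`: "not determined" (no result reported)

Notes on the series. Compound 1 has no result of its own in an assay on isolated protein for inhibition of serine/threonine-protein kinase PLK1 (Homo sapiens), read by Z'-LYTE, with a stated time of 60 min; a higher number here means a weaker inhibitor, a lower number a stronger inhibitor; of the three measured compounds only compound 2 carries a number, and for compound 3 none was reported either. No comparison between two numbers is therefore possible within the measured set, and compound 1 cannot be placed on a scale.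

The compound still to be tested is compound 4 `CCOc1cc(C2CCN(C)CC2)ccc1Nc1ncc2c(n1)N(Cc1cccc(Br)c1)[C@H](CC)C(=O)N2C`. Relative to compound 1 the change is 3-bromophenyl in place of 4-bromophenyl on a saturated chain carbon bound to a nitrogen on an aromatic ring in a ring. Since compound 1 has no value, the size of this step in this assay cannot be read from the data; the nearest measured neighbour of compound 4 is compound 2, which shares the core and differs only in the halogen carried on the benzyl group. Compound 4 is expected to land close to compound 2, because compound 2 gives 540 nM and a bromine for chlorine swap at the same position would normally stay within scatter. Compound 4 is estimated at 500 nM, within 150 nM to 1600 nM.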

Compound 4, half-maximal inhibitory concentration: 540 nM
Estimate against measurement, compound 4: 1.1-fold (0.03 log units) below; low and high end bracket the measured number.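

In this assay, among these compounds, bromo in place of chloro on an aromatic carbon of the benzyl group gives no change at the digits printed from compound 2 to compound 4 (within the scatter) and is the first step that can be read. In this one pair, the two halogens cannot be told apart at this position, although that finding rests on compound 2 and compound 4 alone. No measured evidence explains why the two halogens read alike.

Steps involving compound 1 or compound 3 cannot be read, so the change from 4-bromobenzyl to 3-bromobenzyl and the effect of methoxy remain open. Also open, on these data alone, is whether an amine or a carboxylic acid carried on the benzyl group in place of the halogen would stay level with compound 4 at 540 nM in this assay.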